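Methyl to methoxy on the anilino ring of compound 2

The source may report more compounds than this note shows. Statements on the series, on what has been measured and on what is new or still open speak of the compounds shown alone.

Compound 1: `COc1cccc(Nc2nc(N)c(C(=O)c3ccccc3)s2)c1`, 2900 nM
Compound 2: `COc1cc(C(=O)c2sc(Nc3ccc(C)cc3)nc2N)cc(OC)c1OC`, 41 nM

For the measured compounds named here, in a functional assay on CCRF-CEM cells (Homo sapiens) for antiproliferative activity, read by cell counting, with a stated time of 2 days (on this read-out lower numbers stand for stronger inhibition and higher numbers for weaker inhibition), compound 2 gives the lower of the two numbers known so far, and compound 1 gives 2900 nM, a gap that lies well beyond the scatter; the two compounds differ in several places, so the figures are simply set side by side. Compound 3, `COc1ccc(Nc2nc(N)c(C(=O)c3cc(OC)c(OC)c(OC)c3)s2)cc1`, is not yet measured. It departs from compound 2 in one place: methoxy in place of methyl on an aromatic carbon. In this assay, a change of this kind, methoxy in place of methyl on an aromatic carbon, is expected to move the number only a little, so the step from compound 2 to compound 3 is estimated at a 1.2-fold higher number from compound 2 to compound 3 (0.09 log units; within the scatter), which is within the scatter. Compound 3 is therefore expected to give about 50 nM, with a range from 15 nM to 170 nM.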

Compound 3, half-maximal inhibitory concentration: 1100 nM
The estimate for compound 3 lay 22-fold (1.34 log units) below the measured number, and the stated range ends below it.
By their numbers in this assay, from the lowest: compound 2; then compound 3; then compound 1.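

In this assay, replacing (4-methylphenyl)amino with (4-methoxyphenyl)amino gives a 27-fold higher number from compound 2 to compound 3 (1.43 log units; beyond the scatter), so at this place, para to a large group, methoxy and methyl are not interchangeable. Compound 1 and compound 2 differ in several places and could tie no change to a single site, whereas this pair ties a large loss to one substituent, with the rest of the structure held constant. Nothing measured here accounts for the size of this step.

On these data alone, what remains open is whether the loss follows the oxygen of the methoxy group or the longer substituent, and what an ethyl group, a chlorine atom or a hydroxyl group would give at the same carbon. The compounds shown also leave open whether the step would be as large with a different group on the carbonyl of the shared core.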